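Piperidinyl carbonyl in place of an open amine chain

The source may report more compounds than this note shows. Statements on the series, on what has been measured and on what is new or still open speak of the compounds shown alone.

Going by the values given here, compound 2 `COc1cccc2c1c(NS(=O)(=O)c1ccc(Cl)s1)nn2Cc1cccc(CNC(=O)C(C)(C)N)c1` gives 5 L/kg in an ADME assay on the whole organism (strain Beagle) for pharmacokinetics, with Canis familiaris (Canis lupus familiaris) as the target, at a dose of 0.5 mg/kg by the intravenous route (a lower number here means that more of the compound stays in the plasma, a higher number that more of the compound sits outside the plasma), the lowest of the two numbers measured so far, with compound 1 `CN[C@H](C)C(=O)NCc1cccc(Cn2nc(NS(=O)(=O)c3ccc(Cl)s3)c3c(OC)cccc32)c1` nearest at 6 L/kg. Among the compounds with values here, the only measured step, a 1.2-fold lower number from compound 1 to compound 2 (0.08 log units; within the scatter), sits within the scatter, so the two compounds cannot be told apart on this read-out. Compound 3 `COc1cccc2c1c(NS(=O)(=O)c1ccc(Cl)s1)nn2Cc1cccc(CNC(=O)[C@@H]2CCCCN2)c1` has not yet been measured; it differs from compound 2 by piperidin-2-yl in place of 1-amino-1-methylethyl on a carbonyl carbon. Within the data shown here, no measured step covers this particular exchange. Among the measured compounds shown here, the one step that alters the same group on the carbonyl carbon, the one from compound 1 to compound 2, brought no change beyond the scatter, and that is the sole guide available. Compound 3 is therefore expected to show no change at the digits printed from compound 2 to compound 3 (within the scatter), which means no step beyond the scatter in either direction. Compound 3 is estimated at 5 L/kg, within a range from 2.5 L/kg to 10 L/kg.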

Compound 3, volume of distribution at steady state in the Canis familiaris assay: 11 L/kg
Compound 3: the middle estimate sits 2.2-fold (0.34 log units) below what was measured; the whole stated range lies below it.
By their numbers in the Canis familiaris assay, from the lowest: compounds 2, 1 and 3 (each within the scatter of the next, the first and the last beyond it).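

Going by these compounds alone, in the Canis familiaris assay, compound 3 gives 11 L/kg, and piperidin-2-yl on the carbonyl carbon gives the first step at this position that lies beyond the scatter, a 2.2-fold higher number from compound 2 to compound 3 (0.34 log units; beyond the scatter), so this place does respond to the group it carries, which the step between the two open chains could not show. Against the other open chain, 1-(methylamino)ethyl, the same ring gives a 1.8-fold higher number from compound 1 to compound 3 (0.26 log units; within the scatter), which stays within the scatter, so the change is clearly resolved only against 1-amino-1-methylethyl. Nothing available bears on what lies behind this step.

The compounds shown leave open how a pyrrolidin-2-yl group on the carbonyl carbon would compare, and so whether the six-membered ring itself matters. In a physicochemical assay for acid dissociation, compound 2 gives "not determined" (no result reported) and compound 3 gives "not determined" (no result reported), so that read-out cannot be compared for this change.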